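Changing the Aryl Substituent: From Chloro to Benzyloxy

The compounds below may be only part of what the source reports. "The series", "measured", "known", "first", "only" and "open" are said of these compounds alone.

The measured compounds:
- Compound 1, `CC(=O)n1cc(/C=C(/C(=O)O)c2ccc(Cl)cc2)c2cc(OCc3ccccc3)ccc21`. In a functional assay on LNCaP cells (Homo sapiens) for cytotoxicity, read by MTT assay, with a stated time of 72 h (a higher number here means a weaker inhibitor, a lower number a stronger inhibitor), compound 1 gives > 100000 nM, which is a limit of the assay rather than a number.
- Compound 2, `COc1ccc(/C(=C\c2cn(C(C)=O)c3ccc(OCc4ccccc4)cc23)C(=O)O)cc1OC`. In this assay compound 2 gives > 100000 nM, again a limit of the assay.
- Compound 3, `COc1cccc(/C(=C\c2cn(C(C)=O)c3ccc(OCc4ccccc4)cc23)C(=O)O)c1`. In this assay compound 3 gives 65100 nM.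

From the compounds shown here alone, compound 1 therefore stands at the limit of > 100000 nM in this assay, at which 2 of the 3 values shown sit, so its exact position among the three is unknown. The steps that alter the same aryl group are a step that the two limits leave unreadable from compound 1 to compound 2 and an at least 1.5-fold lower number from compound 1 to compound 3 (0.18 log units; that floor lies within the scatter); the further step an at least 1.5-fold lower number from compound 2 to compound 3 (0.18 log units; that floor lies within the scatter) links the two methoxy variants. All three changes on that aryl ring left the numbers near or at the limit.

The step to compound 4, `CC(=O)n1cc(/C=C(/C(=O)O)c2ccc(OCc3ccccc3)cc2)c2cc(OCc3ccccc3)ccc21`, is benzyloxy in place of chloro on an aromatic carbon. For the measured compounds named here, no measured step exchanges chloro for benzyloxy, so the expectation rests only on the observation that every alteration of this aryl group so far stayed near the limit. The step is therefore expected to be a number no higher from compound 1 to compound 4 (the limit leaves the size open), no change beyond the scatter. In this assay compound 4 is estimated at 100000 nM, within 40000 nM to 300000 nM, most likely reported only as a limit.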

Compound 4, half-maximal inhibitory concentration: 77700 nM
Beside the measured number, compound 4's estimate is 1.3-fold (0.11 log units) above it; the measured number falls inside the stated range.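

With benzyloxy on this aromatic carbon, para to a large group, compound 4 gives a real measured number in this assay, 77700 nM, so a group of 8 heavy atoms carrying its own six-membered aromatic ring can replace a single chlorine and still give a value that can be read. The change amounts to an at least 1.2-fold lower number from compound 1 to compound 4 (0.10 log units; that floor lies within the scatter), which means the data show no loss from this much larger group but also no gain that clears the usual scatter. From the compounds shown here alone, only a floor can be given for this step, and its true size stays unknown because compound 1 sits at a limit and not at a number: the limit of > 100000 nM in this assay, at which 2 of the 4 values shown sit.

The compounds shown leave open what an amine or a plain phenyl group on this same carbon would give, and so whether the oxygen or the ring of benzyloxy matters more for the result. They also leave open whether any group at this position can bring the number down by a step clearly beyond the scatter.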